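Ethoxy in place of benzylsulfanyl: expected whole-animal activity

The source may hold more compounds than are shown below. What is called first, only, known or untested is meant among the compounds shown, and "the series" means these compounds.

Of the compounds shown here, three have been tested in a functional assay on the whole organism (strain NMRI) with Mus musculus as the target, with a stated time of 60 min, at a dose of 10 mg/kg by the intraperitoneal route; on this read-out higher numbers stand for a stronger effect at the one dose given and lower numbers for a weaker effect. Compound 1 `CSc1nnc(Cc2ccccc2Oc2ccccc2)[nH]1` gives 133%, compound 2 `CCSc1nnc(Cc2ccccc2Oc2ccccc2)[nH]1` gives 142%, and compound 3 `c1ccc(CSc2nnc(Cc3ccccc3Oc3ccccc3)[nH]2)cc1` gives 139%. Compound 3 sits among the other two: the change a number 6 percentage points higher from compound 1 to compound 3 (within the scatter) and the change a number 3 percentage points lower from compound 2 to compound 3 (within the scatter) are both within the scatter, as is a number 9 percentage points higher from compound 1 to compound 2 (within the scatter), so the three numbers cannot be told apart.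

Compound 4 `CCOc1nnc(Cc2ccccc2Oc2ccccc2)[nH]1` carries ethoxy in place of benzylsulfanyl on an aromatic carbon. For the measured compounds named here, none of the measured steps touches this spot in the same way: each of them only varies the substituent on the saturated chain carbon bound to a sulfur, and every one of them stayed within the scatter. As far as these compounds go, the sulfur itself and the ring of the leaving group have not been varied anywhere, so the effect of their loss is unknown. Given that the three measured steps were all small, no step beyond the scatter is expected for a number 9 percentage points lower from compound 3 to compound 4 (within the scatter) in this assay, though the range is kept wide. Compound 4 is therefore estimated at 130%, between 100% and 160%.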

Compound 4, a percentage reported as activity, at one dose (the size of the read-out at that dose, not a potency): 126%
Compound 4: middle estimate off by 4 percentage points, on the high side; the measured number falls inside the stated range.
By their numbers in this assay, from the lowest: compounds 4, 1, 3 and 2 (each within the scatter of the next, the first and the last beyond it).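

For the compounds shown here, at the aromatic carbon between two ring nitrogen atoms, ethoxy gives the first steps beyond the scatter in this assay: a number 13 percentage points lower from compound 3 to compound 4 (beyond the scatter) and a number 16 percentage points lower from compound 2 to compound 4 (beyond the scatter), whereas a number 7 percentage points lower from compound 1 to compound 4 (within the scatter) does not leave it. The step from ethylsulfanyl to ethoxy keeps the ethyl chain and changes only the linking atom from sulfur to oxygen, so this position is not indifferent to that atom, although the methylsulfanyl compound 1 cannot be separated from compound 4. No measured information bears on the reason for these steps.

As far as these compounds go, whether methoxy, propoxy or an amine at this carbon would group with ethoxy or with the sulfur-linked compounds remains open. Also open, from the compounds shown here alone, is whether these differences in effect at a single dose would hold at other doses.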